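This account rests on a few compounds, and the source may have more. Where it says the series, first, only, none or still open, it means among the compounds named here.

Measured in an ADME assay on NIH3T3 cells (Mus musculus) for inhibition, read by MTT assay, with a stated time of 48 h; a lower number here means a stronger inhibitor, a higher number a weaker inhibitor:
Compound 1 `CS(=O)(=O)c1ccc(-c2nc3ccccn3c2Sc2ccccc2)cc1`: > 100000 nM, a limit
Compound 2 `c1ccc(Sc2c(-c3ccccc3)nc3ccc(-c4ccccc4)cn23)cc1`: > 100000 nM, a limit
Compound 3 `CSc1ccc(-c2nc3ccccn3c2Sc2ccccc2)cc1`: > 100000 nM, a limit

Compound 3 gives no number, only the limit > 100000 nM. It shares that position with the other two compounds: the limit of > 100000 nM in this assay, at which 3 of the 3 values shown sit. The next compound is compound 4 `c1ccc(Sc2c(-c3ccsc3)nc3ccccn23)cc1`, with thiophen-3-yl in place of 4-(methylsulfanyl)phenyl on an aromatic carbon. Going by the values given here, the one measured step, a step that the two limits leave unreadable from compound 1 to compound 3, changes the group that now leaves, but it offers no size to carry over. The expectation therefore rests on the limit alone, and no step beyond the scatter is expected in this assay. A further reading at the limit is the likeliest outcome. The expected step is a number no higher from compound 3 to compound 4 (the limit leaves the size open). Compound 4 is estimated at 100000 nM, with an expected range of 50000 nM to 200000 nM.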

Compound 4, half-maximal inhibitory concentration: 94100 nM
Compound 4: middle estimate off by 1.1-fold (0.03 log units), on the high side, and the stated range covers the measured number.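

In this assay compound 4 gives 94100 nM, the only actual number among the compounds shown, so a change at this position on the five-membered aromatic ring can yield a reading that is not a limit. Thiophen-3-yl in place of 4-(methylsulfanyl)phenyl gives an at least 1.0-fold lower number from compound 3 to compound 4 (0.02 log units; that floor lies within the scatter); this is only a floor on the size of the change, and the step between the two limits cannot be read. The reading for compound 4 therefore separates it from the others only as a number against a limit: the limit of > 100000 nM in this assay, at which 3 of the 4 values shown sit.

Still open, on these data alone, is how far the number moves at this position with a furan-3-yl ring, a pyridin-3-yl ring, an amine or a carboxylic acid on the ring, or a longer alkyl chain. Also open, as far as these compounds go, is whether the sulfur of thiophen-3-yl matters, or only the smaller ring.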